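Methyl in Place of Hydrogen on the Shared Core

The compounds below may be only part of what the source reports. "The series", "measured", "known", "first", "only" and "open" are said of these compounds alone.

Going by the values given here, compound 2 `O=C(CCCCC(=O)Nc1nc2ccccc2s1)NO` holds the only number here in a functional assay on PC-3 cells (Homo sapiens) for cytotoxicity; on this read-out lower numbers stand for stronger inhibition and higher numbers for weaker inhibition: compound 2 gives 12.5 ug/mL. Compound 1 `CS(=O)(=O)c1ccc2nc(NC(=O)CCCCC(=O)NO)sc2c1` reaches only a limit of this assay, > 30 ug/mL. Among the compounds with values here, that limit, (the limit of > 30 ug/mL in this assay, at which 1 of the 2 values shown sits), bounds the single measured step, an at least 2.4-fold lower number from compound 1 to compound 2 (0.38 log units; beyond the scatter), which exchanges a methylsulfonyl for hydrogen. Compound 3 `Cc1ccc2nc(NC(=O)CCCCC(=O)NO)sc2c1` instead differs from compound 2 by methyl in place of hydrogen on an aromatic carbon. Within the data shown here, no measured step exchanges hydrogen for methyl, so the step is expected to stay within the scatter: a 1.3-fold lower number from compound 2 to compound 3 (0.10 log units; within the scatter). Compound 3 is therefore estimated at 10 ug/mL, within 4 ug/mL to 25 ug/mL.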

Compound 3, half-maximal inhibitory concentration: 6.23 ug/mL
The estimate for compound 3 lay 1.6-fold (0.21 log units) above the measured number; measured number inside the range.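

Methyl in place of hydrogen on this aromatic carbon gives a 2.0-fold lower number from compound 2 to compound 3 (0.30 log units; within the scatter), so the two cannot be told apart on this read-out. Methyl in place of methylsulfonyl on the same carbon gives an at least 4.8-fold lower number from compound 1 to compound 3 (0.68 log units; beyond the scatter), which shows that the separation from methylsulfonyl is not confined to hydrogen. The size of that step is bounded by the value of compound 1, which is a limit: the limit of > 30 ug/mL in this assay, at which 1 of the 3 values shown sits.

The compounds shown leave open whether a methoxy group, a chlorine atom or an amine on this carbon would read like methyl or like methylsulfonyl. They also leave open how a longer chain would change these numbers.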